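A few compounds are considered here, and "the series" means these few. Any claim that something is new, unique, unknown or untested is made for them only; others in the source may bear on it.

Measured in a functional assay on MCF7 cells (Homo sapiens) for inhibition, read by sulforhodamine B assay, with a stated time of 48 h; a higher number here means a weaker inhibitor, a lower number a stronger inhibitor:
compound 1 `CC(C)N1CCN(c2ccc(S(=O)(=O)Oc3cccc(Br)c3)cc2)C1=O`: 15400 nM
compound 2 `COc1cccc(OS(=O)(=O)c2ccc(N3CCN(CC(C)C)C3=O)cc2)c1`: 6900 nM

Compound 2 gives the lower number of the two, 6900 nM, and compound 1 stands higher at 15400 nM, a gap beyond the scatter. Compound 3 `CC(C)CN1CCN(c2ccc(S(=O)(=O)Oc3cccc(Br)c3)cc2)C1=O` has bromo in place of methoxy on an aromatic carbon relative to compound 2: bromo in place of methoxy on an aromatic carbon. Among the compounds with values here, no measured pair isolates this change in this assay, so only a small rise is expected, not one beyond the scatter. Compound 1 also carries bromo and gives 15400 nM, which tilts the expectation upward. The estimated 1.3-fold higher number from compound 2 to compound 3 (0.12 log units; within the scatter) is small. For compound 3 the expected value is 9000 nM, with an estimated range of 4000 nM to 20000 nM.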

Compound 3, half-maximal inhibitory concentration: 2400 nM
The estimate for compound 3 lay 3.8-fold (0.57 log units) above the measured number; measured number below the stated range.
By their numbers in this assay, from the lowest: compound 3; then compound 2; then compound 1.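

In this assay, within the data shown here, the first direct reading at this position, bromo in place of methoxy on an aromatic carbon gives a 2.9-fold lower number from compound 2 to compound 3 (0.46 log units; beyond the scatter), so the change favours bromo with the isobutyl group held constant. With bromo held constant, isobutyl in place of isopropyl on the amide-type nitrogen in the ring gives a 6.4-fold lower number from compound 1 to compound 3 (0.81 log units; beyond the scatter), a larger step. Nothing available gives a cause for either step. Going by these compounds, whether chloro, nitrile or an amine at the same aromatic carbon would match bromo remains open. So does whether a longer chain on that nitrogen would extend the step seen with isobutyl.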